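This account rests on a few compounds, and the source may have more. Where it says the series, first, only, none or still open, it means among the compounds named here.

Compound 1 `Oc1ccc(Cl)cc1-n1ccnc1` and compound 2 `Nc1ccc(Cl)cc1-n1ccnc1` share one core and differ in a single group. In an assay on cells for inhibition of Indoleamine 2,3-dioxygenase 1 (Homo sapiens), read by HPLC, with a stated time of 20 min (on this read-out lower numbers stand for stronger inhibition and higher numbers for weaker inhibition), compound 1 gives 2100 nM, while compound 2 gives 88000 nM. That step, a 42-fold higher number from compound 1 to compound 2 (1.62 log units; beyond the scatter), comes from the change (amino in place of hydroxy on an aromatic carbon).

Compound 3 `Oc1ccc(Cl)cc1-c1nnc[nH]1` carries a different core; how it differs from the core of compound 1 is not broken down here. In this assay compound 3 gives 600 nM, the lowest of the three numbers.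

Compound 4 `Nc1ccc(Cl)cc1-c1nnc[nH]1` is built from compound 3 by the same change, (amino in place of hydroxy on an aromatic carbon), at a place described in identical words. The expectation rests on the measured step of a 42-fold higher number from compound 1 to compound 2 (1.62 log units; beyond the scatter). A step of similar size is expected, namely a 42-fold higher number from compound 3 to compound 4 (1.62 log units; beyond the scatter). Compound 4 is therefore expected to give about 25000 nM, estimated to lie between 8000 nM and 80000 nM.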

Compound 4, half-maximal inhibitory concentration: 35 nM
Estimate against measurement, compound 4: 710-fold (2.85 log units) above; the measured number lies below the stated range.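

In this assay, the change of amino in place of hydroxy does not carry over from one core to the other: it now gives a 17-fold lower number from compound 3 to compound 4 (1.23 log units; beyond the scatter), opposite in direction to the earlier step. Set side by side, the two steps clearly differ: the same change on two cores in this assay, a 42-fold higher number (1.62 log units; beyond the scatter) from compound 1 to compound 2 and a 17-fold lower number (1.23 log units; beyond the scatter) from compound 3 to compound 4, 720-fold (2.86 log units) apart, beyond the scatter of two such steps

Within the data shown here, this shows that the effect of this change depends on the core in these compounds, but two cores make only one comparison, and the numbers do not explain the reversal or predict the result on a further core.

The compounds shown leave open how a methoxy or methylamino group in the same place would behave on either core. They also leave open whether fluoro in place of chloro would alter the reversal.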